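The source may hold more compounds than are shown below. What is called first, only, known or untested is meant among the compounds shown, and "the series" means these compounds.

Series notes. The shared core carries a side chain on the carbonyl carbon of the aryl ketone, and that chain is what varies across the set. Compound 1 `CCCc1c(COc2ccc(C(=O)C(C)Cc3nnn[nH]3)cc2)ccc(C(C)=O)c1O` gives 7.18 in a functional assay on ileum (Cavia porcellus) with cysteinyl leukotriene receptor (Homo sapiens) as the target; a lower number here means a less potent compound, a higher number a more potent compound, by a factor of ten per unit of this negative logarithm. Compound 2 `CCCc1c(COc2ccc(C(=O)CCCC(=O)O)cc2)ccc(C(C)=O)c1O` gives 6.81 in this assay, the lowest of the two single numbers at hand, with compound 1 as its nearest neighbour. Compound 3 `CCc1c(COc2ccc(C(=O)CC(C)(C)CC(=O)O)cc2)ccc(C(C)=O)c1O` gives 7.46; 7.6 (2 entries) in this assay, entered more than once, as shown by the several entries of compound 3 in this assay, 7.46; 7.6 (2 entries). Among the measured compounds shown here, the one measured step, a number 0.37 log units lower from compound 1 to compound 2 (beyond the scatter), leaves the open-chain acid a modest margin behind the tetrazole-bearing branched chain.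

Compound 4 `CCCc1c(COc2ccc(C(=O)CC(C)(C)CC(=O)O)cc2)ccc(C(C)=O)c1O` is not yet measured in this assay. The change from compound 2 reads (1-(carboxymethyl)-1-methylethyl in place of 2-carboxyethyl on a saturated chain carbon bound to a carbonyl carbon). The step from compound 1 to compound 2 concerned a different exchange of the whole chain and is not a direct guide to this branching. Compound 3 carries the same 1-(carboxymethyl)-1-methylethyl group on a core that differs elsewhere and gives 7.46; 7.6 (2 entries) in this assay; that is the closest pointer available. An upward step beyond the scatter is expected, a number 0.59 log units higher from compound 2 to compound 4 (beyond the scatter). Compound 4 is estimated at 7.4 in this assay, with a range from 6.9 to 7.9.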

Compound 4, negative logarithm of the antagonist equilibrium constant: 7.73
The estimate for compound 4 lay 0.33 log units below the measured number, and the stated range covers the measured number.
By their numbers in this assay, from the lowest: compound 2; then compound 1; then compound 4.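

In this assay, the carboxylic acid chain does not stay at the low level of compound 2: with 1-(carboxymethyl)-1-methylethyl in place of 2-carboxyethyl on a saturated chain carbon bound to a carbonyl carbon, the result is a number 0.92 log units higher from compound 2 to compound 4 (beyond the scatter). The earlier order of the acid and the tetrazole-bearing chain therefore does not hold for every acid, since a different acid chain gives a number 0.55 log units higher from compound 1 to compound 4 (beyond the scatter), which places compound 4 above both compound 1 and compound 2 among the compounds with a single number. The same 1-(carboxymethyl)-1-methylethyl group also stands on compound 3, on a core that differs elsewhere, so this chain has now been seen on two cores, with this record for the second: the several entries of compound 3 in this assay, 7.46; 7.6 (2 entries)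

The compounds shown do not separate the contribution of each added carbon, and a chain with a single methyl group or with the two methyl groups closed into a cyclopropyl ring would address that. Going by these compounds, it also remains open whether a tetrazole in place of the carboxylic acid on this branched chain would give a number above or below that of compound 4.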